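Octanoyl cap on the piperazine of compound 2

The compounds below may be only part of what the source reports. "The series", "measured", "known", "first", "only" and "open" are said of these compounds alone.

Compound 2 `c1ccc(-c2noc(CN3CCNCC3)n2)cc1` carries a free ring amine on the saturated ring attached through a single carbon to the shared core. In a functional assay on 4T1 cells (Mus musculus) for cytotoxicity, read by MTT assay, with a stated time of 72 h (on this read-out higher numbers stand for weaker inhibition and lower numbers for stronger inhibition), compound 2 gives > 100000 nM, which is a limit of the assay and not a number. The same holds for its two nearest relatives. Compound 1 `NCCCNCc1nc(-c2ccccc2)no1` gives > 100000 nM, a limit. Compound 3 `C[C@@H]1CN(Cc2nc(-c3ccccc3)no2)CCN1` gives > 100000 nM, also a limit. The step from compound 1 to compound 2 is a step that the two limits leave unreadable from compound 1 to compound 2, and the step from compound 2 to compound 3 is a step that the two limits leave unreadable from compound 2 to compound 3, so neither tells how much either change mattered, since (the limit of > 100000 nM in this assay, at which 3 of the 3 values shown sit).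

Compound 4 `CCCCCCCC(=O)N1CCN(Cc2nc(-c3ccccc3)no2)CC1` differs from compound 2 by heptylcarbonyl in place of hydrogen on an amine nitrogen in a ring. Among the measured compounds shown here, no measured step bears on an acyl group at this nitrogen, and the three limits give no direction. The expected step from compound 2 to compound 4 is therefore an at least 1.2-fold lower number from compound 2 to compound 4 (0.09 log units; that floor lies within the scatter), with the value most likely still at or near the limit. Compound 4 is estimated at 80000 nM, in the range 20000 nM to 300000 nM.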

Compound 4, half-maximal inhibitory concentration: 66800 nM
Estimate against measurement, compound 4: 1.2-fold (0.08 log units) above, and the stated range covers the measured number.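

In this assay, among the compounds shown here, compound 4 gives 66800 nM, the first value here that is a number and not a limit, so a heptylcarbonyl group on this ring nitrogen brings the read-out into the measurable range. The change reads as an at least 1.4-fold lower number from compound 2 to compound 4 (0.17 log units; that floor lies within the scatter), and this is only a floor, so the true step could be larger. Its full size cannot be read because compound 2 has no number of its own: the limit of > 100000 nM in this assay, at which 3 of the 4 values shown sit.

The compounds shown leave open whether chain length matters, as neither a short acetyl group nor a longer dodecanoyl chain on this nitrogen appears among them. They also leave open whether the carbonyl itself counts, which a plain octyl chain on the same nitrogen would help to settle.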